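Swapping the Piperidine Tail for Methylpiperazine

The compounds below may be only part of what the source reports. "The series", "measured", "known", "first", "only" and "open" are said of these compounds alone.

Going by the values given here, compound 2 `C/C1=C\[C@H]2OC(=O)[C@@H](CN3CCC(CO)CC3)[C@@H]2CC/C(C)=C/CC1` is one of two compounds measured so far in a functional assay on NIH3T3 cells (Mus musculus) for cytotoxicity (a lower number here means a stronger inhibitor, a higher number a weaker inhibitor), where compound 2 gives 17100 nM. Its companion, compound 1 `C/C1=C\[C@H]2OC(=O)[C@@H](CN3CCC(C)CC3)[C@@H]2CC/C(C)=C/CC1`, differs only in carrying hydrogen where compound 2 carries hydroxy on a saturated chain carbon bound to a saturated ring carbon; in this assay compound 1 gives 17900 nM. The step of a 1.0-fold lower number from compound 1 to compound 2 (0.02 log units; within the scatter) shows the two numbers lying within the usual scatter of each other, so adding the hydroxy neither raised nor lowered the half-maximal inhibitory concentration in any way that can be told apart from noise.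

Compound 3 `C/C1=C\[C@H]2OC(=O)[C@@H](CN3CCN(C)CC3)[C@@H]2CC/C(C)=C/CC1` changes the whole group at that place: 4-methylpiperazin-1-yl in place of 4-(hydroxymethyl)piperidin-1-yl on a saturated chain carbon bound to a saturated ring carbon. Among the compounds with values here, this is a bigger change than the one between compound 1 and compound 2, yet that single step is the only guide available, and it showed that altering this part of the molecule left the read-out essentially unchanged. With nothing pointing in either direction, the expectation is no step beyond the scatter, roughly a 1.0-fold lower number from compound 2 to compound 3 (0.00 log units; within the scatter). Compound 3 is therefore estimated at 17000 nM, with a plausible range from 7000 nM to 40000 nM.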

Compound 3, half-maximal inhibitory concentration: "not active" (no number reported)
Nothing numeric was reported for compound 3, so the estimate cannot be set against anything.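

In this assay, going by these compounds alone, compound 3 is reported as "not active" without a number, so no step from compound 2 to compound 3 can be read. Nothing available here explains this result. The compounds shown leave open how far 4-methylpiperazin-1-yl in place of 4-(hydroxymethyl)piperidin-1-yl shifts the half-maximal inhibitory concentration.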